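Solubility notes: core variation and alkyl substituent size

The source may report more compounds than this note shows. Statements on the series, on what has been measured and on what is new or still open speak of the compounds shown alone.

Measured compounds so far:
- compound 1, `Cc1cn2c(N3CC[C@H](N(C)C)C3)c(-c3ccccc3)c(C)c(C#N)c2n1`: 356 ug/mL
- compound 2, `Cc1c(-c2ccccc2)c(N2CC[C@H](N(C)C)C2)n2cc(C(C)(C)C)nc2c1C#N`: 27 ug/mL
- compound 3, `Cc1c(-c2ccccc2)c(N2CC[C@H](N(C)C)C2)n2nc(C(C)(C)COCc3ccccc3)nc2c1C#N`: < 3 ug/mL

In a physicochemical assay for solubility, at pH 6.8 (on this read-out higher numbers stand for higher solubility and lower numbers for lower solubility), compound 1 gives 356 ug/mL. Compound 2 gives 27 ug/mL in this assay, a drop of a 13-fold lower number from compound 1 to compound 2 (1.12 log units; beyond the scatter). For compound 3 this assay reports only a limit, < 3 ug/mL, so its true position is not known beyond that; this is the case described by the limit of < 3 ug/mL in this assay, at which 1 of the 3 values shown sits.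

The unmeasured compound 4, `CCc1nc2c(C#N)c(C)c(-c3ccccc3)c(N3CC[C@H](N(C)C)C3)n2n1`, shares the core of compound 3 and differs from it in one place: ethyl in place of 1-((benzyloxy)methyl)-1-methylethyl on an aromatic carbon. For the measured compounds named here, the only measured step that bears on this is the one from compound 1 to compound 2, where a larger alkyl group on an aromatic carbon gave a 13-fold lower number from compound 1 to compound 2 (1.12 log units; beyond the scatter). The change from compound 3 to compound 4 runs the other way, towards a far smaller group, so a large step upward in this assay is expected, although compound 3 being a limit means the size of that step cannot be fixed. The expected step is an at least 33-fold higher number from compound 3 to compound 4 (1.52 log units; beyond the scatter). Compound 4 is therefore estimated at 100 ug/mL, with a plausible range from 20 ug/mL to 400 ug/mL.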

Compound 4, solubility: 228 ug/mL
Estimate against measurement, compound 4: 2.3-fold (0.36 log units) below, within the range that was stated.
By their numbers in this assay, from the lowest: compound 2; then compounds 4 and 1 (each within the scatter of the next). At a limit, below all of these: compound 3.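

On the core of compound 3, the group on the aromatic carbon between two ring nitrogen atoms carries a large effect in this assay: ethyl in place of 1-((benzyloxy)methyl)-1-methylethyl gives an at least 76-fold higher number from compound 3 to compound 4 (1.88 log units; beyond the scatter). For the compounds shown here, the earlier step showed a change of alkyl group on the core of compound 1 only, so this is the first read on the core of compound 3, and it runs upward, with compound 4 at 228 ug/mL. Compound 3 has only a limit, < 3 ug/mL, so the step has a floor and no fixed size: the limit of < 3 ug/mL in this assay, at which 1 of the 4 values shown sits.

The change removes a six-membered aromatic ring, an oxygen and the branched carbon together, so the compounds shown do not say which of these parts accounts for the step. Open on this core are tert-butyl, which would link this step to the one on the core of compound 1, a longer alkyl chain, and a group such as an amine or a carboxylic acid at the same place, each of which would show how far the read-out in this assay follows the size of the group.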